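Methoxyamino Replaces Methoxy on a Shared Nucleoside Core

The source may report more compounds than this note shows. Statements on the series, on what has been measured and on what is new or still open speak of the compounds shown alone.

Compound 1 `C[C@@]1(O)[C@H](O)[C@@H](CO)O[C@H]1n1cnc2c(NO)nc(N)nc21` was examined in an ADME assay on PBMC cells (Homo sapiens) for cytotoxicity, read by trypan blue exclusion, with a stated time of 6 days; on this read-out higher numbers stand for lower toxicity in this test and lower numbers for higher toxicity in this test. In this assay compound 1 gives only a limit of > 100000 nM. Compound 2 `COc1nc(OC)c2ncn([C@@H]3O[C@H](CO)[C@@H](O)[C@@]3(C)O)c2n1` likewise reaches only the limit of > 100000 nM in this assay. Compound 3 `COc1nc(N)c2ncn([C@@H]3O[C@H](CO)[C@@H](O)[C@@]3(C)O)c2n1` also stops at the limit of > 100000 nM in this assay. The step that the two limits leave unreadable from compound 2 to compound 3 thus cannot be sized, and all three values rest on (the limit of > 100000 nM in this assay, at which 3 of the 3 values shown sit). Compound 4 `CONc1nc(N)c2ncn([C@@H]3O[C@H](CO)[C@@H](O)[C@@]3(C)O)c2n1` differs from compound 3 by methoxyamino in place of methoxy on an aromatic carbon. Within the data shown here, no measured step bears on this change, and the three limits give no size for any step at all. In this assay compound 4 is therefore expected to show a step that the limit leaves unreadable from compound 3 to compound 4 and an estimated value of 150000 nM, ranging from 80000 nM to 400000 nM.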

Compound 4, half-maximal cytotoxic concentration: > 100000 nM
Compound 4: a limit, no number; the forecaster's own chance of this, stated with the estimate: 85%; the middle value is on the limit's open side.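

In this assay, among these compounds, compound 4 gives > 100000 nM as a limit and not a number, so no step from compound 3 to compound 4 can be read. The compounds shown leave open whether methoxyamino in place of methoxy shifts the half-maximal cytotoxic concentration at all, as the values offer only this: the limit of > 100000 nM in this assay, at which 4 of the 4 values shown sit.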